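Swapping Nitro for Bromo on a Benzophenone Aromatase Inhibitor

This account rests on a few compounds, and the source may have more. Where it says the series, first, only, none or still open, it means among the compounds named here.

Compound 1 `O=C(c1ccccc1)c1ccccc1Cn1ccnc1` gives 560 nM in an assay on microsomes from placenta for inhibition of Aromatase (Homo sapiens); on this read-out higher numbers stand for weaker inhibition and lower numbers for stronger inhibition.
Compound 2 `O=C(c1ccccc1)c1cc([N+](=O)[O-])ccc1Cn1ccnc1` gives 25.9 nM in this assay.
Compound 3 `O=C(c1ccc(-c2ccccc2)cc1)c1cc([N+](=O)[O-])ccc1Cn1ccnc1` gives 17.7 nM in this assay.

Among these three, compound 2 stands second highest in this assay; compound 3 lies within the scatter of it, while compound 1 sits well above it. Putting the nitro in place of hydrogen gave a 22-fold lower number from compound 1 to compound 2 (1.33 log units; beyond the scatter), and adding a phenyl gave a 1.5-fold lower number from compound 2 to compound 3 (0.17 log units; within the scatter). Compound 4 `O=C(c1ccccc1)c1cc(Br)ccc1Cn1ccnc1` differs from compound 2 by bromo in place of nitro on an aromatic carbon. Among the measured compounds shown here, only the nitro step bears on this change: it shows a large gain over hydrogen, and no measured compound tells how bromo compares with either. The bromo change is therefore expected to hand back part of that gain, a step of a 3.1-fold higher number from compound 2 to compound 4 (0.49 log units; beyond the scatter) in this assay. Compound 4 is expected to come in near 80 nM, within a range of 25 nM to 300 nM.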

Compound 4, half-maximal inhibitory concentration: 400 nM
For compound 4 the middle estimate is 5.0-fold (0.70 log units) below the measured one; the measured number lies above the stated range.
By their numbers in this assay, from the lowest: compounds 3 and 2 (each within the scatter of the next); then compounds 4 and 1 (each within the scatter of the next).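

At this position, para to a (1H-imidazol-1-yl)methyl group, replacing nitro with bromo gives a 15-fold higher number from compound 2 to compound 4 (1.19 log units; beyond the scatter), whereas replacing hydrogen with bromo gives a 1.4-fold lower number from compound 1 to compound 4 (0.15 log units; within the scatter). The large gain seen earlier therefore does not come with every group placed here: it appears with nitro but not with bromo. Nothing measured here explains the difference between these two groups. Still open, going by these compounds, is whether a nitrile, an amine or a carboxylic acid at this place would behave like nitro or like bromo, and whether adding the phenyl of compound 3 would change the number when bromo replaces nitro.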